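Chain-shortened lactone amides: phenyl in place of benzyl

The source may report more compounds than this note shows. Statements on the series, on what has been measured and on what is new or still open speak of the compounds shown alone.

Measured so far:
compound 1, `O=C(CCCCCCCc1ccccc1)N[C@H]1CCOC1=O`, in a functional assay on NCI-H630 cells (Homo sapiens) for cytotoxicity, read by sulforhodamine B assay, with a stated time of 5 days (on this read-out lower numbers stand for stronger inhibition and higher numbers for weaker inhibition), gives > 100000 nM, a limit of the assay.
compound 3, `O=C(CCCCCCc1ccccc1)N[C@H]1CCOC1=O`, in this assay gives > 100000 nM, a limit of the assay.
compound 2, `O=C(CCCCCCCCCc1ccccc1)CC(=O)N[C@H]1CCOC1=O`, in this assay gives 13000 nM, the only number among the three.

Compound 1 and compound 3 differ by phenyl in place of benzyl on a saturated chain carbon, six bonds along the chain from a carbonyl carbon. Both sit at the limit of > 100000 nM in this assay, at which 2 of the 3 values shown sit, so a step that the two limits leave unreadable from compound 1 to compound 3 cannot be read. The difference between the core of compound 1 and the core of compound 2 is not broken down here.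

Compound 4, `O=C(CCCCCCCCc1ccccc1)CC(=O)N[C@H]1CCOC1=O`, is not yet measured. It differs from compound 2 by phenyl in place of benzyl on a saturated chain carbon, eight bonds along the chain from a carbonyl carbon, the same kind of change as from compound 1 to compound 3, but here on a saturated chain carbon eight bonds along the chain from a carbonyl carbon rather than six.

The measured pair gives no readable size for this change, so the expectation for compound 4 rests on compound 2 at 13000 nM with a step of about a 1.5-fold higher number from compound 2 to compound 4 (0.19 log units; within the scatter) expected. In this assay compound 4 is estimated at 20000 nM, expected between 6000 nM and 70000 nM.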

Compound 4, half-maximal inhibitory concentration: 10000 nM
Compound 4: the middle estimate sits 2.0-fold (0.30 log units) above what was measured; the measured number falls inside the stated range.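

In this assay, phenyl in place of benzyl on a saturated chain carbon, eight bonds along the chain from a carbonyl carbon, gives a 1.3-fold lower number from compound 2 to compound 4 (0.11 log units; within the scatter), so no change can be claimed at this place. The same kind of change on the core of compound 1 leaves no size to read, with both members of that pair resting on a limit of the assay: the limit of > 100000 nM in this assay, at which 2 of the 4 values shown sit. Carrying the change from one core to another thus stays untested: a single readable step stands alone, and it shows neither that the result transfers between cores nor that it fails to.

Open, going by these compounds, is whether the same result holds with a longer chain before the phenyl, or with a carboxylic acid or an amine in place of phenyl at the chain end. Also open, on these data alone, is what in the core of compound 2 goes with its value of 13000 nM; the difference from the core of compound 1 is not broken down here.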